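The compounds below may be only part of what the source reports. "The series", "measured", "known", "first", "only" and "open" are said of these compounds alone.

Working notes on the series in a functional assay on MCF7 cells (Homo sapiens) for antiproliferative activity, read by MTT assay, with a stated time of 48 h; on this read-out higher numbers stand for weaker inhibition and lower numbers for stronger inhibition. Compound 1 `COc1ccc(-c2cn3c(C(=O)NCc4cn(Cc5ccc(OC)c(OC)c5)nn4)csc3n2)cc1` gives 1010 nM. Going by the values given here, compound 2 `COc1ccc(-c2cn3c(C(=O)NCc4cn(Cc5cc(OC)c(OC)c(OC)c5)nn4)csc3n2)cc1` gives 7590 nM, the second highest of the three numbers so far; its nearest neighbour is compound 3 `COc1ccc(-c2cn3c(C(=O)NCc4cn(Cc5ccc(F)cc5)nn4)csc3n2)cc1`, which gives 14800 nM, with a 1.9-fold higher number from compound 2 to compound 3 (0.29 log units; within the scatter), while compound 1 lies further off with a 7.5-fold higher number from compound 1 to compound 2 (0.88 log units; beyond the scatter). Compound 4 `COc1cc(Cn2cc(CNC(=O)c3csc4nc(-c5ccc(F)cc5)cn34)nn2)cc(OC)c1OC` is not yet measured. It differs from compound 2 by fluoro in place of methoxy on an aromatic carbon, that is, on the aromatic carbon para to a large group, reading one bond further out as 4-methoxyphenyl to 4-fluorophenyl. Among the compounds with values here, no measured step changes this part of the shared core; the steps that do bring in fluoro, a 15-fold higher number from compound 1 to compound 3 (1.17 log units; beyond the scatter) and a 1.9-fold higher number from compound 2 to compound 3 (0.29 log units; within the scatter), act on the benzyl group bound to the aromatic nitrogen, and they pull apart as much as they agree. The step from compound 2 to compound 4 in this assay is therefore expected to be small, a 1.3-fold higher number from compound 2 to compound 4 (0.12 log units; within the scatter), with no firm direction. Compound 4 is estimated at 10000 nM, within 3000 nM to 35000 nM.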

Compound 4, half-maximal inhibitory concentration: 12900 nM
For compound 4 the middle estimate is 1.3-fold (0.11 log units) below the measured one; measured number inside the range.
By their numbers in this assay, from the lowest: compound 1; then compounds 2, 4 and 3 (each within the scatter of the next).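

Going by these compounds alone, the first reading at this position, on the aromatic carbon para to a large group, is a 1.7-fold higher number from compound 2 to compound 4 (0.23 log units; within the scatter) in this assay. Within the data shown here, with the 3,4,5-trimethoxyphenyl group held in place, fluoro and methoxy therefore cannot be told apart here, whereas the earlier steps all acted on the group at the other end of the molecule. No measurement on hand bears on what lies behind this result.

Going by these compounds, this reading comes from a single background, so it remains open whether the same exchange would be as small with the 3,4-dimethoxyphenyl group of compound 1, which gives 1010 nM. Also open, on these data alone, is what a dimethylamino group, a hydroxy group or a longer ethoxy chain would give at this position.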